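The compounds below may be only part of what the source reports. "The series", "measured", "known", "first", "only" and "open" are said of these compounds alone.

Notes on the series, followed in a functional assay on NCI-H1299 cells (Homo sapiens) for cytotoxicity, read by MTT assay, with a stated time of 48 h; on this read-out lower numbers stand for stronger inhibition and higher numbers for weaker inhibition. Within the data shown here, compound 2 `CC(=O)/C=C1/C(=O)N2[C@@H]1SC(C)(C)[C@@H]2C(=O)OC(c1ccccc1)c1ccccc1` gives 24200 nM in this assay, the lowest of the two numbers so far. The other measured compound, compound 1 `CC1(C)S[C@@H]2/C(=C\C(=O)c3ccco3)C(=O)N2[C@H]1C(=O)OC(c1ccccc1)c1ccccc1`, gives 61500 nM in this assay. Among the measured compounds shown here, the single step between them, a 2.5-fold lower number from compound 1 to compound 2 (0.41 log units; beyond the scatter), came from methyl in place of furan-2-yl on a carbonyl carbon.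

Compound 3 `CC1(C)S[C@@H]2/C(=C\C(=O)c3ccccc3)C(=O)N2[C@H]1C(=O)OC(c1ccccc1)c1ccccc1` is not yet measured. It differs from compound 2 by phenyl in place of methyl on a carbonyl carbon; cut one bond further out, the change reads acetyl to benzoyl. For the measured compounds named here, only the step of a 2.5-fold lower number from compound 1 to compound 2 (0.41 log units; beyond the scatter) bears on this change, and it runs the other way: a methyl replaced an aromatic ring on a carbonyl carbon there, with furan-2-yl rather than phenyl as the ring. Phenyl is not furan-2-yl, so the size is uncertain, but a return to an aromatic group on the carbonyl carbon is expected to give a modest rise in the number, of the order of a 1.9-fold higher number from compound 2 to compound 3 (0.27 log units; within the scatter). On that basis compound 3 is expected to give about 45000 nM in this assay, within a range from 18000 nM to 110000 nM.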

Compound 3, half-maximal inhibitory concentration: 39000 nM
Compound 3: middle estimate off by 1.2-fold (0.06 log units), on the high side; the range from low to high includes it.
By their numbers in this assay, from the lowest: compounds 2, 3 and 1 (each within the scatter of the next, the first and the last beyond it).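

In this assay, replacing acetyl with benzoyl gives a 1.6-fold higher number from compound 2 to compound 3 (0.21 log units; within the scatter) and so does not separate the two groups on the carbonyl carbon, and the comparison with the furan-2-yl ketone gives a 1.6-fold lower number from compound 1 to compound 3 (0.20 log units; within the scatter) and does not separate those two either. Compound 3 thus lies within the scatter of both compound 1 and compound 2, so the series does not support a simple split between methyl and aromatic groups at this position, and only compound 1 and compound 2 remain separated beyond the scatter. Among these compounds, no supporting data bear on why these differences are so small or on what lies behind the one resolved step.

On these data alone, what remains open is whether any group on this carbonyl carbon can move the number well beyond the narrow band spanned by methyl, phenyl and furan-2-yl. An amine, which would turn the ketone into an amide, a carboxylic acid or a longer alkyl chain in this place would test that, as would a phenyl ring carrying a methoxy group or a chlorine atom.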